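Halogen Swap on a Benzylidene Tetralone Series

A few compounds are considered here, and "the series" means these few. Any claim that something is new, unique, unknown or untested is made for them only; others in the source may bear on it.

Measured compounds:
compound 1, `O=C1/C(=C/c2cccc(Cl)c2)CCCc2ccccc21`, 52300 nM
compound 2, `O=C1/C(=C/c2ccc(Cl)cc2)CCCc2ccccc21`, 51800 nM
compound 3, `O=C1/C(=C/c2cccc(Br)c2)CCCc2ccccc21`, 51000 nM

In a functional assay on L1210 cells (Mus musculus) for inhibition (a lower number here means a stronger inhibitor, a higher number a weaker inhibitor), the three measured compounds give numbers that sit close together. Compound 1 and compound 2 share the same atoms joined differently; how their two cores differ is not broken down here. From compound 1 to compound 3 the change is bromo in place of chloro on an aromatic carbon, and the step it made was a 1.0-fold lower number from compound 1 to compound 3 (0.01 log units; within the scatter).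

Compound 4, `O=C1/C(=C/c2ccc(Br)cc2)CCCc2ccccc21`, has not yet been measured. It differs from compound 2 by bromo in place of chloro on an aromatic carbon. This is the same kind of change as that from compound 1 to compound 3, though the place differs: meta to a large group there, para to a large group here. Because the earlier step was a 1.0-fold lower number from compound 1 to compound 3 (0.01 log units; within the scatter), the step from compound 2 to compound 4 is expected to be a 1.0-fold lower number from compound 2 to compound 4 (0.01 log units; within the scatter). Compound 4 is therefore estimated at 51000 nM, between 30000 nM and 90000 nM.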

Compound 4, half-maximal inhibitory concentration: 50900 nM
Beside the measured number, compound 4's estimate is 1.0-fold (0.00 log units) above it, within the range that was stated.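

In this assay the swap of bromo for chloro on the second core gave a 1.0-fold lower number from compound 2 to compound 4 (0.01 log units; within the scatter). Set beside the earlier step, the result carries over from one core to the other, with the halogen in a different place on the aromatic ring: the same change on two cores in this assay, a 1.0-fold lower number (0.01 log units; within the scatter) from compound 1 to compound 3 and a 1.0-fold lower number (0.01 log units; within the scatter) from compound 2 to compound 4, 1.0-fold (0.00 log units) apart, within the scatter of two such steps. Within the data shown here, this shows only that the swap made no step beyond the scatter on either core; it does not show that a change with a real effect would carry over in the same way, nor does it reach past these two cores.

The compounds shown leave open whether an amine or a carboxylic acid in the halogen's place would move the number. They also leave open whether a fluoro group would behave as chloro and bromo do.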